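One More Methyl on a Branched Chain

A few compounds are considered here, and "the series" means these few. Any claim that something is new, unique, unknown or untested is made for them only; others in the source may bear on it.

Among the measured compounds shown here, only two solubility numbers are known so far for this series. In a physicochemical assay for solubility, in phosphate buffer, at pH 6.5 (on this read-out higher numbers stand for higher solubility and lower numbers for lower solubility), compound 1 `C=C[C@@H]1C[C@]1(NC(=O)[C@@H]1C[C@@H](Oc2nccc3cc(OC)ccc23)CN1C(=O)[C@@H](NC(=O)N[C@@H](C)COC)C(C)(C)C)C(=O)NS(=O)(=O)C1CC1` gives 1070 ug/mL and compound 2 `C=C[C@@H]1C[C@]1(NC(=O)[C@@H]1C[C@@H](Oc2nccc3cc(OC)ccc23)CN1C(=O)[C@@H](NC(=O)N[C@H](COC)C(C)C)C(C)(C)C)C(=O)NS(=O)(=O)C1CC1` gives 570 ug/mL. Compound 2 has the lower of these two numbers, but the pair lies within the scatter of repeated measurements, so the numbers do not separate the two compounds.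

The next compound, compound 3 `C=C[C@@H]1C[C@]1(NC(=O)[C@@H]1C[C@@H](Oc2nccc3cc(OC)ccc23)CN1C(=O)[C@@H](NC(=O)N[C@H](COC)[C@@H](C)CC)C(C)(C)C)C(=O)NS(=O)(=O)C1CC1`, is built from compound 2 by one small change: methyl in place of hydrogen on a saturated chain carbon, three bonds along the chain from an amide-type nitrogen. This places methyl in place of hydrogen on a saturated chain carbon, three bonds along the chain from an amide-type nitrogen, which turns isopropyl into sec-butyl.

For the measured compounds named here, one measured step bears on this change, isopropyl in place of methyl, and it reads a 1.9-fold lower number from compound 1 to compound 2 (0.27 log units; within the scatter). Going by the values given here, because a 1.9-fold lower number from compound 1 to compound 2 (0.27 log units; within the scatter) is the only guide, no step beyond the scatter is expected in this assay. The estimated step is a 1.3-fold lower number from compound 2 to compound 3 (0.10 log units; within the scatter), a slight downward lean that a single step cannot confirm. For compound 3 the expected value is 450 ug/mL, with an estimated range from 200 ug/mL to 1000 ug/mL.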

Compound 3, solubility: 326 ug/mL
Compound 3: the middle estimate sits 1.4-fold (0.14 log units) above what was measured; the range from low to high includes it.
By their numbers in this assay, from the lowest: compounds 3, 2 and 1 (each within the scatter of the next, the first and the last beyond it).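

The added methyl gives a 1.7-fold lower number from compound 2 to compound 3 (0.24 log units; within the scatter), so on its own the change from isopropyl to sec-butyl does not separate these two compounds in this assay. Set against the methyl group of compound 1, however, sec-butyl gives a 3.3-fold lower number from compound 1 to compound 3 (0.52 log units; beyond the scatter), the first gap in this series that lies beyond the scatter; two single steps that could not be told from noise thus add up to a modest difference that can be read across the same position. The data offered here give no explanation for this gap.

Among the compounds shown here, with three compounds, methyl, isopropyl and sec-butyl are the only groups seen at this position, and all three are plain saturated carbon groups, so it remains open whether the numbers would keep falling with a longer chain such as n-pentyl or would level off. As far as these compounds go, it is equally open how this position would respond to a group of a different kind, such as an amine or a carboxylic acid, in place of the sec-butyl group.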